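The source may hold more compounds than are shown below. What is called first, only, known or untested is meant among the compounds shown, and "the series" means these compounds.

Compound 2 `O=C(NCc1ccc(F)cc1)c1cc(Oc2ccc(/C=C/c3ccccn3)cc2)ccn1` was tested in a functional assay on HepG2 cells (Homo sapiens) for antiproliferative activity, read by CCK-8 assay, with a stated time of 48 h (on this read-out higher numbers stand for weaker inhibition and lower numbers for stronger inhibition), where compound 2 gives 45100 nM. Among the measured compounds shown here, its only measured neighbour is compound 1 `COc1ccc(CNC(=O)c2cc(Oc3ccc(/C=C/c4ccccn4)cc3)ccn2)cc1`, which in this assay gives 26000 nM; the step of a 1.7-fold higher number from compound 1 to compound 2 (0.24 log units; within the scatter) separates the two, so they sit within the scatter of each other. Compound 3 `O=C(NC1CCCCC1)c1cc(Oc2ccc(/C=C/c3ccccn3)cc2)ccn1` differs from compound 2 by cyclohexyl in place of 4-fluorobenzyl on an amide-type nitrogen. For the measured compounds named here, no measured step touches this kind of exchange, since the only step known changes a substituent on the 4-fluorobenzyl group rather than replacing it, so the expected step of a 1.1-fold higher number from compound 2 to compound 3 (0.04 log units; within the scatter) is small and uncertain. Compound 3 is therefore estimated at 50000 nM, within 15000 nM to 160000 nM.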

Compound 3, half-maximal inhibitory concentration: 20600 nM
For compound 3 the middle estimate is 2.4-fold (0.39 log units) above the measured one, and the stated range covers the measured number.
By their numbers in this assay, from the lowest: compounds 3, 1 and 2 (each within the scatter of the next, the first and the last beyond it).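

This position on an amide-type nitrogen does not need an aromatic ring: in this assay, cyclohexyl gives a 2.2-fold lower number from compound 2 to compound 3 (0.34 log units; beyond the scatter), a modest change beyond the scatter, and a 1.3-fold lower number from compound 1 to compound 3 (0.10 log units; within the scatter), which stays within it. A non-aromatic ring therefore holds up here against both benzyl groups, and the earlier fluoro and methoxy pair could not show this. No supporting data explain the result.

Still open, from the compounds shown here alone, is whether a cyclopentyl group, a longer chain such as hexyl, or a group carrying an amine or a carboxylic acid would move the number further at this nitrogen.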